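This account rests on a few compounds, and the source may have more. Where it says the series, first, only, none or still open, it means among the compounds named here.

Compound 1 `CC1(C)[C@H]2CC[C@]1(C)N(Cc1cn(-c3ccccc3F)nn1)C(=O)C2`: 150 nM
Compound 2 `CC1(C)[C@H]2CC[C@]1(C)N(Cc1cn(-c3cccc(Cl)c3)nn1)C(=O)C2`: 260 nM

For the measured compounds named here, in a functional assay on PANC-1 cells (Homo sapiens) for inhibition, read by MTT assay, with a stated time of 24 h (a higher number here means a weaker inhibitor, a lower number a stronger inhibitor), compound 2 gives 260 nM, and the only other number available comes from compound 1 at 150 nM. These two values lie within the scatter of each other, so they cannot be ranked.

Compound 3 `Cc1ccc(-n2cc(CN3C(=O)C[C@@H]4CC[C@@]3(C)C4(C)C)nn2)cc1` keeps the shared core and carries 4-methylphenyl in place of 3-chlorophenyl on an aromatic nitrogen. Going by the values given here, no measured compound yet carries this 4-methylphenyl group, so the data offer no direct test of it.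

Among the compounds with values here, one measured step bears on the change, a swap of groups on that same aromatic nitrogen: a 1.7-fold higher number from compound 1 to compound 2 (0.24 log units; within the scatter). It stayed within the scatter, and a single step is a thin guide. Within the data shown here, with only that step to go on, no change beyond the scatter is expected in this assay, in either direction. The expected 1.3-fold lower number from compound 2 to compound 3 (0.11 log units; within the scatter) is small and lies within the scatter. For compound 3 the estimated value is 200 nM, with an expected range from 80 nM to 500 nM.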

Compound 3, half-maximal inhibitory concentration: 270 nM
Compound 3: middle estimate off by 1.4-fold (0.13 log units), on the low side; measured number inside the range.
By their numbers in this assay, from the lowest: compounds 1, 2 and 3 (each within the scatter of the next).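

In this assay, 4-methylphenyl in place of 3-chlorophenyl on this aromatic nitrogen gives a 1.0-fold higher number from compound 2 to compound 3 (0.02 log units; within the scatter), and 4-methylphenyl in place of 2-fluorophenyl gives a 1.8-fold higher number from compound 1 to compound 3 (0.26 log units; within the scatter). Before compound 3 there was only one step at this position, whereas three differently substituted phenyl groups can now be compared, and none of the steps between them goes beyond the scatter, so these three compounds cannot be ranked. Nothing available explains why these three groups give values that cannot be told apart.

All of this rests on a narrow set of groups: 3-chlorophenyl and 4-methylphenyl are both six-membered aromatic rings of carbon only, with no hydrogen-bond donors or acceptors, and 2-fluorophenyl is also a substituted phenyl ring. The compounds shown leave open whether the value would hold with a pyridine ring on this nitrogen, or with a phenyl ring carrying an amine or a carboxylic acid, and whether a longer chain between the nitrogen and the ring would change it.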